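Extending the Phenylcarbamoyl Group with a Methylpyrazole

This account rests on a few compounds, and the source may have more. Where it says the series, first, only, none or still open, it means among the compounds named here.

Compound 1, `NS(=O)(=O)N1CCC(C(=O)/C(=N/O)Nc2ccc(F)c(Br)c2)CC1`, gives 62500 nM in an assay for inhibition of Tryptophan 2,3-dioxygenase (Homo sapiens), with a stated time of 1 h; on this read-out higher numbers stand for weaker inhibition and lower numbers for stronger inhibition.
Compound 2, `O=C(/C(=N/O)Nc1ccc(F)c(Br)c1)C1CCN(C(=O)Nc2ccccc2)CC1`, gives 58000 nM in this assay.

Among the measured compounds shown here, compound 2 stands at the lower of the two numbers, but the only measured step, a 1.1-fold lower number from compound 1 to compound 2 (0.03 log units; within the scatter), lies within the scatter, so compounds 1 and 2 cannot be told apart on these data. Compound 3, `Cn1cc(-c2ccc(NC(=O)N3CCC(C(=O)/C(=N/O)Nc4ccc(F)c(Br)c4)CC3)cc2)cn1`, has not yet been measured. It differs from compound 2 by 1-methyl-1H-pyrazol-4-yl in place of hydrogen on an aromatic carbon. For the measured compounds named here, the one measured step bears only loosely on this change: it swapped the whole group on the amine nitrogen in a ring and left the number where it was, whereas the new change keeps that group and grows it at an aromatic carbon. Going by the values given here, there is no measured precedent for adding a ring at this place, so a modest shift in either direction is as plausible as none. Compound 3 is therefore expected to give about 30000 nM in this assay, with a range from 8000 nM to 120000 nM. That estimate corresponds to an expected step of a 1.9-fold lower number from compound 2 to compound 3 (0.29 log units; within the scatter), leaning slightly toward stronger inhibition but without firm support.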

Compound 3, half-maximal inhibitory concentration: > 100000 nM
Compound 3 was reported as a limit; the forecaster's own chance of this, stated with the estimate: 15%; middle value at least 3.3-fold (0.52 log units) away from the limit.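

Compound 3 is reported in this assay only as a limit of the assay, not as an exact number: the limit of > 100000 nM in this assay, at which 1 of the 3 values shown sits.

From the compounds shown here alone, the step can therefore be read only as a floor, an at least 1.7-fold higher number from compound 2 to compound 3 (0.23 log units; that floor lies within the scatter), and the true size of the change remains unknown, although its direction is clear from the printed limit. Among the compounds shown here, this is the first information about the aromatic carbon of the phenylcarbamoyl group, since the earlier step exchanged the whole group on the amine nitrogen in a ring and said nothing about growing that group outward. Placing 1-methyl-1H-pyrazol-4-yl on this carbon gives no sign of stronger inhibition, so this particular extension offers no gain on this read-out.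

These compounds cannot separate the contribution of the pyrazole ring from that of its methyl group, so an unmethylated 1H-pyrazol-4-yl group would be needed to address that question. Going by these compounds, it also remains open whether something much smaller on the same aromatic carbon, such as a methyl group, a methoxy group, an amine or a carboxylic acid, would leave the number unchanged or move it in either direction.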